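The source may hold more compounds than are shown below. What is called first, only, known or untested is meant among the compounds shown, and "the series" means these compounds.

Measured so far:
- compound 1, `Cc1nc(N2CCC(N3CCCS3(=O)=O)CC2)nc2ccc(NC(=O)/C=C/c3ccc(OC(F)(F)F)cc3)cc12`: 85%
- compound 2, `Cc1nc(N2CCC(O)(C3CC3)CC2)nc2ccc(NC(=O)COc3ccc(OC(F)(F)F)cc3)cc12`: "not determined" (no result reported)

Compound 1 stands alone with a number here; compound 2 carries no result in this read-out, so nothing can be said of how the two compare. Among the compounds with values here, in an ADME assay on microsomes from liver (Homo sapiens) for metabolic stability, with a stated time of 30 min (on this read-out lower numbers stand for a less stable compound and higher numbers for a more stable compound), compound 1 gives 85%, which is the only value shown and the single point of reference for the step that follows.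

Compound 3, `Cc1nc(N2CCC(N3CCNC3=O)CC2)nc2ccc(NC(=O)/C=C/c3ccc(OC(F)(F)F)cc3)cc12`, differs from compound 1 in one place: a group of 6 heavy atoms (3 carbon, 2 nitrogen, 1 oxygen; one five-membered non-aromatic ring with 2 hetero atoms) in place of a group of 7 heavy atoms (3 carbon, 1 nitrogen, 2 oxygen, 1 sulfur; one five-membered non-aromatic ring with 2 hetero atoms), on a saturated ring carbon. Within the data shown here, no step between two measured compounds is available to set a scale for this kind of exchange, so the expectation rests on compound 1 alone. The step from compound 1 to compound 3 is expected to be small, most likely within the usual scatter or a modest decrease: a number 7 percentage points lower from compound 1 to compound 3 (within the scatter). In this assay compound 3 is therefore estimated at 78%, within a range from 55% to 95%.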

Compound 3, percent of the compound remaining: 83%
The estimate for compound 3 lay 5 percentage points below the measured number; measured number inside the range.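

In this assay, within the data shown here, putting 2-oxoimidazolidin-1-yl in place of the sulfur-bearing five-membered ring on the saturated ring carbon gave a number 2 percentage points lower from compound 1 to compound 3 (within the scatter), the first step that can be read at this position. The position therefore carries both groups with values that stand within the scatter of each other, even though the entering group has 1 hydrogen-bond donor and the leaving group has 0 hydrogen-bond donors. No evidence at hand accounts for this result.

As far as these compounds go, whether an amine, a carboxylic acid or a longer chain on this saturated ring carbon would keep the value in the same range remains open. Also open, from the compounds shown here alone, is whether the same exchange would read alike with a different group on the amide of the shared core.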